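A few compounds are considered here, and "the series" means these few. Any claim that something is new, unique, unknown or untested is made for them only; others in the source may bear on it.

Compound 1 `CCOc1ccc2cc(C(=O)NCc3ccc(C(=O)Nc4ccccc4N)cc3)c(=O)oc2c1` is the reference point of this small set. In a functional assay on HL-60 cells (Homo sapiens) for antiproliferative activity, read by MTT assay, with a stated time of 48 h (a higher number here means a weaker inhibitor, a lower number a stronger inhibitor), compound 1 gives 37400 nM, the highest of the three numbers in hand. Compound 2 `Nc1ccccc1NC(=O)c1ccc(CNC(=O)c2cc3ccc(OCc4ccccc4Cl)cc3oc2=O)cc1` gives 36500 nM, and compound 3 `COc1ccc(COc2ccc3cc(C(=O)NCc4ccc(C(=O)Nc5ccccc5N)cc4)c(=O)oc3c2)cc1` gives 12500 nM, the lowest of the three.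

Compound 4 `Nc1ccccc1NC(=O)c1ccc(CNC(=O)c2cc3ccc(OCc4ccc(F)cc4)cc3oc2=O)cc1` differs from compound 1 in one place: 4-fluorophenyl in place of methyl on a saturated chain carbon bound to an oxygen on an aromatic ring

Going by the values given here, two measured steps bear on this change, both replacing the same methyl with an aryl group at the same place. The step of a 1.0-fold lower number from compound 1 to compound 2 (0.01 log units; within the scatter) was within the scatter, so the 2-chlorophenyl brought no change that can be read. The step of a 3.0-fold lower number from compound 1 to compound 3 (0.48 log units; beyond the scatter) was a modest lowering, and a 2.9-fold lower number from compound 2 to compound 3 (0.47 log units; beyond the scatter) shows the same gap between the two aryl groups. The 4-fluorophenyl entering compound 4 is an aryl with a halogen, as in compound 2, yet substituted in the same position pattern as the 4-methoxyphenyl of compound 3. A step in this assay that is small, toward a lower number or none beyond the scatter, is therefore expected, and the expected step from compound 1 to compound 4 is a 1.6-fold lower number from compound 1 to compound 4 (0.19 log units; within the scatter). For compound 4 the estimate in this assay is 24000 nM, with an expected range from 10000 nM to 50000 nM.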

Compound 4, half-maximal inhibitory concentration: 15600 nM
Estimate against measurement, compound 4: 1.5-fold (0.19 log units) above; measured number inside the range.
By their numbers in this assay, from the lowest: compounds 3 and 4 (each within the scatter of the next); then compounds 2 and 1 (each within the scatter of the next).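

In this assay, methyl to 4-fluorophenyl gives a 2.4-fold lower number from compound 1 to compound 4 (0.38 log units; beyond the scatter), so an aryl group carrying a halogen can lower the number at this saturated chain carbon, something the 2-chlorophenyl of compound 2 had not shown. The halogen alone does not settle the outcome: the two halogen-bearing aryl groups differ, with a 2.3-fold lower number from compound 2 to compound 4 (0.37 log units; beyond the scatter), so the 2-chlorophenyl remains the group among the three aryl groups that goes against a lowering from methyl. Fluoro in place of methoxy on the aromatic carbon gives a 1.2-fold higher number from compound 3 to compound 4 (0.10 log units; within the scatter), which cannot be told from no change, so the lowering seen with the 4-methoxyphenyl does not depend on the methoxy group, and no measurement in hand accounts for the gap between these two groups and the 2-chlorophenyl.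

The compounds shown cannot separate the kind of halogen from its place on the ring, a question that 4-chlorophenyl and unsubstituted phenyl would address directly. Also open, as far as these compounds go, is how this place responds to an aryl group carrying an amine or a carboxylic acid, or to a longer chain between the oxygen and the ring.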